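A few compounds are considered here, and "the series" means these few. Any claim that something is new, unique, unknown or untested is made for them only; others in the source may bear on it.

Compound 3 `COc1cc(-c2cc(-c3cc(C(C)C)c(O)cc3C)[nH]c(=O)c2C#N)ccc1O` gives 37.5% in a functional assay for inhibition, tested at 60 ug/mL (on this read-out higher numbers stand for a stronger effect at the one concentration tested and lower numbers for a weaker effect), and stands second highest of the three numbers measured. Compound 1 `Cc1cc(O)c(C(C)C)cc1-c1cc(-c2ccccc2)c(C#N)c(=O)[nH]1` gives 34% in this assay, a value within the scatter of compound 3, as the step of a number 3.5 percentage points higher from compound 1 to compound 3 (within the scatter) shows. Compound 2 `COc1ccc(-c2cc(-c3cc(C(C)C)c(O)cc3C)[nH]c(=O)c2C#N)c(OC)c1` gives 48.5% in this assay, and the step of a number 11 percentage points lower from compound 2 to compound 3 (beyond the scatter) lies beyond the scatter. Compound 4 `Cc1cc(O)c(C(C)C)cc1-c1cc(-c2ccco2)c(C#N)c(=O)[nH]1` differs from compound 3 by furan-2-yl in place of 4-hydroxy-3-methoxyphenyl on an aromatic carbon. Both measured steps exchange the group at this same carbon; one stayed within the scatter and one was modest, so the position tolerates exchange without large swings. Within the data shown here, no measured step introduces a five-membered ring, so the direction is uncertain, and a step within or just beyond the scatter is expected, most likely downward. Compound 4 is therefore estimated at 32% in this assay, with a range of 18% to 46%, which means an expected step of a number 5.5 percentage points lower from compound 3 to compound 4 (within the scatter).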

Compound 4, a percentage reported as inhibition, at one concentration (the size of the read-out at that concentration, not a potency): 55.2%
Compound 4: middle estimate off by 23.2 percentage points, on the low side, outside the stated range (above it).
By their numbers in this assay, from the lowest: compounds 1 and 3 (each within the scatter of the next); then compounds 2 and 4 (each within the scatter of the next).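

In this assay, the carbon opposite the ring nitrogen proves to accept a five-membered aromatic ring with one hetero atom, since furan-2-yl gives a number 17.7 percentage points higher from compound 3 to compound 4 (beyond the scatter) and also a number 21.2 percentage points higher from compound 1 to compound 4 (beyond the scatter) in place of the six-membered rings of carbon only. Against 2,4-dimethoxyphenyl the same exchange gives a number 6.7 percentage points higher from compound 2 to compound 4 (within the scatter) and so separates neither group from the other. No measurement here accounts for these steps. The compounds shown leave open whether the furan oxygen itself matters, and whether a thiophene ring or an amine on this carbon would hold the number.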